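A few compounds are considered here, and "the series" means these few. Any claim that something is new, unique, unknown or untested is made for them only; others in the source may bear on it.

Compound 1, `O=C(CCc1ccccc1)Nc1cc2nc(C3CCCCC3)[nH]c2cc1N1CCCC1`, was tested in an ADME assay on Vero cells (Chlorocebus sabaeus) for cytotoxicity, read by resazurin assay, with a stated time of 3 days (a lower number here means a stronger inhibitor, a higher number a weaker inhibitor), and gave only a limit, > 100 ug/mL, so no number is known for it. Compound 2, `CN(C)c1cc2[nH]c(C3CCCCC3)nc2cc1NC(=O)c1ccc(F)cc1`, likewise reached only a limit, > 100 ug/mL, in this assay. The whole picture so far is the limit of > 100 ug/mL in this assay, at which 2 of the 2 values shown sit. Compound 3, `CCCCNC(=O)Nc1cc2nc(C3CCCCC3)[nH]c2cc1N1CCCC1`, carries butylamino in place of phenethyl on a carbonyl carbon relative to compound 1. Nothing has been measured on either side of this change, so no shift beyond the usual scatter is expected, and compound 3 is estimated at 150 ug/mL, between 50 ug/mL and 500 ug/mL, most likely again reported as a limit, as a step that the limit leaves unreadable from compound 1 to compound 3.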

Compound 3, half-maximal inhibitory concentration: > 100 ug/mL
Compound 3 ended at the assay's limit; the forecaster's own chance of this, stated with the estimate: 80%; the middle value does not contradict the limit.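

Compound 1 and compound 3 both give only limits in this assay, so no step can be read between them. The compounds shown leave open the actual value of each one, and so whether any structural change shifts it: the limit of > 100 ug/mL in this assay, at which 3 of the 3 values shown sit.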